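The source may hold more compounds than are shown below. What is called first, only, known or untested is meant among the compounds shown, and "the series" means these compounds.

Measured compounds:
Compound 1 `O=C1N=C(N2N=C(c3ccc(Br)cc3)CC2c2ccc(Cl)cc2)S/C1=C1\C(=O)Nc2ccc(Cl)cc21` gives 7400 nM in a functional assay on Mino cells (Homo sapiens) for cytotoxicity, read by MTT assay, with a stated time of 72 h; a higher number here means a weaker inhibitor, a lower number a stronger inhibitor.
Compound 2 `O=C1N=C(N2N=C(c3ccccc3)CC2c2ccc(Cl)cc2)S/C1=C1\C(=O)Nc2ccccc21` gives "not determined" (no result reported) in this assay, so no number is available for it.
Compound 3 `O=C1N=C(N2N=C(c3ccc(Cl)cc3)CC2c2ccc(Cl)cc2)S/C1=C1\C(=O)Nc2ccccc21` gives 68200 nM in this assay.

Compound 3 stands highest among the two numbers available: its value lies well above that of compound 1, and the gap between the two is beyond the scatter of repeated measurements. Compound 2 adds no number to this picture.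

Compound 4 `O=C1N=C(N2N=C(c3ccc(Br)cc3)CC2c2ccc(Cl)cc2)S/C1=C1\C(=O)Nc2ccccc21` differs from compound 3 in a single place: bromo in place of chloro on an aromatic carbon. The shared core of the two is otherwise unchanged. Going by the values given here, no pair of measured compounds differs in exactly this way, so there is no directly comparable step to lean on. Compound 1 carries bromo on the same ring but also differs from compound 3 elsewhere, and its value therefore cannot be read as a clean measure of this exchange. For a swap of chloro for bromo on an aromatic carbon, the step from compound 3 to compound 4 is expected to be small, if anything a slight move toward a lower number, and likely within the scatter, as a 1.7-fold lower number from compound 3 to compound 4 (0.23 log units; within the scatter) expresses. Compound 4 is accordingly estimated at 40000 nM, with a range from 15000 nM to 110000 nM.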

Compound 4, half-maximal inhibitory concentration: 10000 nM
Compound 4: middle estimate off by 4.0-fold (0.60 log units), on the high side; the whole stated range lies above it.
By their numbers in this assay, from the lowest: compounds 1 and 4 (each within the scatter of the next); then compound 3.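

In this assay, the change from 4-chlorophenyl to 4-bromophenyl proves to be more than a trivial exchange of one halogen for another, giving a 6.8-fold lower number from compound 3 to compound 4 (0.83 log units; beyond the scatter) at this position on the shared core. The other new comparison concerns a different aromatic carbon, where hydrogen in place of chloro gives a 1.4-fold higher number from compound 1 to compound 4 (0.13 log units; within the scatter) and so leaves no readable difference while 4-bromophenyl is present. Nothing reported here explains why the halogen exchange produces a step of this size.

Going by these compounds, it remains open whether the same halogen step would appear with chloro on the second aromatic carbon, as in compound 1. How an amine or a methoxy group in the same place on the ring would compare with chloro and bromo is also unresolved.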